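Dropping the boronic acid from a chalcone

The source may report more compounds than this note shows. Statements on the series, on what has been measured and on what is new or still open speak of the compounds shown alone.

Compound 1 `O=C(/C=C/c1ccc(B(O)O)cc1)c1ccc[nH]1`: 38000 nM
Compound 2 `O=C(/C=C/c1ccc(I)cc1)c1ccc(OCB(O)O)cc1`: 38000 nM

In a functional assay on MCF-10A cells (Homo sapiens) for inhibition (a lower number here means a stronger inhibitor, a higher number a weaker inhibitor), compound 1 gives 38000 nM, and compound 2 gives 38000 nM; the two values are level within the usual scatter. Compound 3 `O=C(/C=C/c1ccccc1)c1ccc[nH]1` has not been measured. It differs from compound 1 by a hydrogen atom in place of a group of 3 heavy atoms (1 boron, 2 oxygen; no ring), on an aromatic carbon. Among the measured compounds shown here, no step between measured compounds is available to lean on, so the change is judged from the structures alone. The expected step is a 1.3-fold higher number from compound 1 to compound 3 (0.12 log units; within the scatter), which is a small loss or none beyond the scatter. Compound 3 is estimated at 50000 nM, with a range from 12000 nM to 200000 nM.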

Compound 3, half-maximal inhibitory concentration: 63000 nM
For compound 3 the middle estimate is 1.3-fold (0.10 log units) below the measured one, and the stated range covers the measured number.
By their numbers in this assay, from the lowest: compounds 1, 2 and 3 (each within the scatter of the next).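

In this assay, putting a hydrogen atom in place of the boronic acid on this aromatic carbon gives a 1.7-fold higher number from compound 1 to compound 3 (0.22 log units; within the scatter) and so makes no change that can be told from the scatter. At this position, on the core of compound 1, inhibition therefore does not measurably depend on the boronic acid. No measurement at hand explains this result.

A carboxylic acid or an amine on the same aromatic carbon remains untested in the compounds shown. Going by these compounds, whether compound 2 would likewise tolerate losing its boron-bearing group also stays open.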